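The compounds below may be only part of what the source reports. "The series", "measured", "known", "first", "only" and "open" are said of these compounds alone.

Measured compounds:

Compound 1 `Cc1cc(C)c(Oc2cc(Nc3ccc(C#N)cc3)ncc2C(=O)NCc2cn(Cc3ccccc3[N+](=O)[O-])nn2)c(C)c1` — in an ADME assay on MT4 cells (Homo sapiens) for cytotoxicity, read by MTT assay, with a stated time of 5 days (a higher number here means that more compound is tolerated, a lower number that less compound is tolerated), compound 1 reaches only a limit of the assay, > 212000 nM.
Compound 2 `Cc1cccc(Cn2cc(CNC(=O)c3cnc(Nc4ccc(C#N)cc4)cc3Oc3c(C)cc(C)cc3C)nn2)c1` — in this assay compound 2 gives 114000 nM.
Compound 3 `Cc1cc(C)c(Oc2cc(Nc3ccc(C#N)cc3)ncc2C(=O)NCc2cn(Cc3ccc([N+](=O)[O-])cc3)nn2)c(C)c1` — in this assay compound 3 again stands at a limit, >= 139000 nM.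

Compound 1 thus stands at the upper edge of what was measured: its value is a limit (the limit of > 212000 nM in this assay, at which 1 of the 3 values shown sits), and among the three values shown only compound 2 has a numeric value at all, while compound 3 sits at a second limit (the limit of >= 139000 nM in this assay, at which 1 of the 3 values shown sits). Compound 4 `CCOC(=O)CCn1cc(CNC(=O)c2cnc(Nc3ccc(C#N)cc3)cc2Oc2c(C)cc(C)cc2C)nn1` differs from compound 1 by (ethoxycarbonyl)methyl in place of 2-nitrophenyl on a saturated chain carbon bound to an aromatic nitrogen. The measured steps that bear on this change both start from compound 1 and alter the same position: an at least 1.8-fold lower number from compound 1 to compound 2 (0.26 log units; that floor lies within the scatter) and a step that the two limits leave unreadable from compound 1 to compound 3. Neither step is readable as a change beyond the scatter. All three measured compounds are tolerated at very high concentration in this assay, and the change to compound 4 is expected to leave this unchanged, with no step beyond the scatter, so that an at least 1.4-fold lower number from compound 1 to compound 4 (0.15 log units; that floor lies within the scatter) is expected. Compound 4 is therefore estimated at 150000 nM, between 60000 nM and 300000 nM, quite possibly again reported only as a limit.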

Compound 4, half-maximal cytotoxic concentration: 21500 nM
Compound 4: middle estimate off by 7.0-fold (0.84 log units), on the high side, and the stated range ends above it.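

In this assay, among these compounds, (ethoxycarbonyl)methyl in place of the aryl groups on this saturated chain carbon gives the first steps at this position that read beyond the scatter: an at least 9.8-fold lower number from compound 1 to compound 4 (0.99 log units; beyond the scatter), an at least 6.4-fold lower number from compound 3 to compound 4 (0.81 log units; beyond the scatter), and a 5.3-fold lower number from compound 2 to compound 4 (0.72 log units; beyond the scatter). Among compound 1, compound 2 and compound 3, which carry 2-nitrophenyl, 3-methylphenyl and 4-nitrophenyl, no step read beyond the scatter, so the high tolerance they share does not extend to compound 4, which has no ring in this group. Nothing measured here accounts for this drop. The compounds shown leave open whether it follows from losing the phenyl ring or from gaining the ethoxycarbonyl group. A plain propyl chain or a carboxylic acid at this place could separate the two.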